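A few compounds are considered here, and "the series" means these few. Any claim that something is new, unique, unknown or untested is made for them only; others in the source may bear on it.

Measured compounds:
compound 1 `COc1cc(-c2nc(SCc3cn(CC(=O)NC(=O)Nc4ccccn4)nn3)nc(Nc3ccc(C)cc3)c2C#N)cc(OC)c1OC`, 21000 nM
compound 2 `COc1cc(-c2nc(SCc3cn(CC(=O)NC(=O)Nc4ccccn4)nn3)nc(Nc3cccc(C(F)(F)F)c3)c2C#N)cc(OC)c1OC`, 8140 nM
compound 3 `COc1cc(-c2nc(SCc3cn(CC(=O)NC(=O)Nc4ccccn4)nn3)nc(Nc3ccc(Cl)cc3)c2C#N)cc(OC)c1OC`, 45100 nM

Of the compounds shown here, three sharing one core have been tested in a functional assay on MCF7 cells (Homo sapiens) for inhibition, read by MTT assay, with a stated time of 72 h; a lower number here means a stronger inhibitor, a higher number a weaker inhibitor. Compound 1 stands second highest of the three numbers: compound 3 sits a little above it a 2.1-fold higher number from compound 1 to compound 3 (0.33 log units; beyond the scatter), and compound 2 sits below it a 2.6-fold lower number from compound 1 to compound 2 (0.41 log units; beyond the scatter). The widest gap runs from compound 2 to compound 3 a 5.5-fold higher number from compound 2 to compound 3 (0.74 log units; beyond the scatter). All three steps change only the group on the anilino nitrogen.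

Compound 4 `Cc1ccc(Nc2nc(SCc3cn(CC(=O)NC(=O)Nc4ccccn4)nn3)nc(-c3ccc(C)cc3)c2C#N)cc1` differs from compound 1 in another place: 4-methylphenyl in place of 3,4,5-trimethoxyphenyl on an aromatic carbon. None of the three measured steps touches this position, so they give no direct guide to the size or direction of the change from compound 1 to compound 4. The three values show only that this series as a whole gives rather high numbers in this assay, with modest spread.

With nothing to anchor it, compound 4 is expected to land in the same broad region as compound 1, perhaps a little higher, as a modest step of a 1.9-fold higher number from compound 1 to compound 4 (0.28 log units; within the scatter). The estimate for compound 4 is 40000 nM, within a range from 10000 nM to 150000 nM.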

Compound 4, half-maximal inhibitory concentration: 39600 nM
Estimate against measurement, compound 4: 1.0-fold (0.00 log units) above; measured number inside the range.
By their numbers in this assay, from the lowest: compound 2; then compounds 1, 4 and 3 (each within the scatter of the next, the first and the last beyond it).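

In this assay, among these compounds, this is the first step at the aromatic carbon ortho to the cyano group: 4-methylphenyl in place of 3,4,5-trimethoxyphenyl gives a 1.9-fold higher number from compound 1 to compound 4 (0.28 log units; within the scatter). So, for this pair, the ring that enters has 7 heavy atoms, fewer than the ring that leaves, and 0 hydrogen-bond acceptors rather than 3, yet the step stays within the usual scatter of repeated measurements. Nothing else measured for these compounds offers an explanation for this result.

This single pair cannot show whether the position tolerates other groups, such as a 4-aminophenyl ring, a 4-carboxyphenyl ring or a plain methyl. It also leaves open whether the same swap would give a similar result alongside the 3-(trifluoromethyl)phenyl group of compound 2.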